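The source may report more compounds than this note shows. Statements on the series, on what has been measured and on what is new or still open speak of the compounds shown alone.

Three compounds share one core. Compound 1 `Cc1ccccc1N(C)C(=O)c1ccc(-c2ccc(O)c(F)c2)o1` gives 11 nM in an assay on cytosol from placenta for inhibition of 17-beta-hydroxysteroid dehydrogenase type 1 (Homo sapiens), read by HPLC, with a stated time of 10 min, in the presence of a further agent that is not named here; on this read-out lower numbers stand for stronger inhibition and higher numbers for weaker inhibition. Compound 2 `Cc1cccc(F)c1N(C)C(=O)c1ccc(-c2ccc(O)cc2)o1` gives 310 nM in this assay, and compound 3 `Cc1ccc(F)cc1N(C)C(=O)c1ccc(-c2ccc(O)cc2)o1` gives 41 nM. Compound 3 therefore stands second of the three, weaker than compound 1 and stronger than compound 2, both gaps lying beyond the scatter. Compound 4 `Cc1cc(F)ccc1N(C)C(=O)c1ccc(-c2ccc(O)cc2)o1` differs from compound 3 only in the ring on the amide-type nitrogen: 4-fluoro-2-methylphenyl in place of 5-fluoro-2-methylphenyl on an amide-type nitrogen. For the measured compounds named here, the one measured step that bears on this is a 7.6-fold lower number from compound 2 to compound 3 (0.88 log units; beyond the scatter), which shows that shifting the fluorine around that ring can matter. Going by the values given here, with only that step to go on, the step from compound 3 to compound 4 is expected to be about a 1.2-fold higher number from compound 3 to compound 4 (0.09 log units; within the scatter). Compound 4 is thus expected to give about 50 nM, within a range from 15 nM to 160 nM.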

Compound 4, half-maximal inhibitory concentration: 23 nM
Estimate against measurement, compound 4: 2.2-fold (0.34 log units) above; the range from low to high includes it.
By their numbers in this assay, from the lowest: compound 1; then compounds 4 and 3 (each within the scatter of the next); then compound 2.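

In this assay, 4-fluoro-2-methylphenyl in place of 5-fluoro-2-methylphenyl gives a 1.8-fold lower number from compound 3 to compound 4 (0.25 log units; within the scatter) and so cannot be told apart from it. The same ring in place of 2-fluoro-6-methylphenyl gives a 13-fold lower number from compound 2 to compound 4 (1.13 log units; beyond the scatter), so among these three rings on the amide-type nitrogen, only the one in compound 2 stands apart. No evidence here gives a reason for that gap. Still open, on these data alone, is how a chlorine or a methoxy group would compare with fluorine on this ring. As far as these compounds go, the effect of the fluorine itself also stays open, since compound 1 differs from these compounds in more than one place.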